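Methyl to Trifluoromethyl on a Shared Aromatic Core

The source may report more compounds than this note shows. Statements on the series, on what has been measured and on what is new or still open speak of the compounds shown alone.

Compound 1 `Fc1ccc(-c2cc(/C=N/c3ccccc3)on2)cc1` gives 36500 nM in a functional assay on PC-3 cells (Homo sapiens) for inhibition, read by MTT assay, with a stated time of 24 h; on this read-out higher numbers stand for weaker inhibition and lower numbers for stronger inhibition. Compound 2 `Cc1ccc(-c2cc(/C=N/c3ccccc3)on2)cc1` gives 31600 nM in this assay, the lowest of the two numbers shown, although the step of a 1.2-fold lower number from compound 1 to compound 2 (0.06 log units; within the scatter) lies within the scatter. Compound 3 `FC(F)(F)c1ccc(-c2cc(/C=N/c3ccccc3)on2)cc1` carries trifluoromethyl in place of methyl on an aromatic carbon. Going by the values given here, the only measured step that bears on this change is a 1.2-fold lower number from compound 1 to compound 2 (0.06 log units; within the scatter), where one small group replaced another on an aromatic carbon and the number stayed within the scatter. A step of similar size, a 1.0-fold lower number from compound 2 to compound 3 (0.01 log units; within the scatter), is expected here. Compound 3 is therefore estimated at 31000 nM in this assay, within a range from 12000 nM to 80000 nM.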

Compound 3, half-maximal inhibitory concentration: 35700 nM
Compound 3: middle estimate off by 1.2-fold (0.06 log units), on the low side, and the stated range covers the measured number.
By their numbers in this assay, from the lowest: compounds 2, 3 and 1 (each within the scatter of the next).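

Trifluoromethyl on this aromatic carbon, para to a large group, keeps the number in this assay within the scatter of methyl (a 1.1-fold higher number from compound 2 to compound 3 (0.05 log units; within the scatter)) and of fluoro (a 1.0-fold lower number from compound 1 to compound 3 (0.01 log units; within the scatter)). Going from 1 heavy atom in methyl to 4 in trifluoromethyl therefore gives no separable reading, and compounds 1, 2 and 3 cannot be told apart. No measurement shown here accounts for this flat result. From the compounds shown here alone, whether an amine, a carboxylic acid or a longer chain at this place would read the same stays open, as does the effect of changes elsewhere on the shared core.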